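Amine variation on the shared core: toward compound 4

A few compounds are considered here, and "the series" means these few. Any claim that something is new, unique, unknown or untested is made for them only; others in the source may bear on it.

Three members of the series share one core and differ only in the amine on a saturated chain carbon bound to an aromatic carbon. Compound 1 `CCN(CC)Cc1c(O)ccc2oc(Cc3ccccc3)cc12` carries diethylamino, and in a functional assay on SQ20B cells (Homo sapiens) for cytotoxicity, read by MTT assay, with a stated time of 72 h (a higher number here means a weaker inhibitor, a lower number a stronger inhibitor), compound 1 gives 12000 nM. Compound 2 `CN(Cc1ccccc1)Cc1c(O)ccc2oc(Cc3ccccc3)cc12` carries benzyl(methyl)amino and gives 12000 nM; no change at the digits printed from compound 1 to compound 2 (within the scatter). Compound 3 `CON(C)Cc1c(O)ccc2oc(Cc3ccccc3)cc12` carries methoxy(methyl)amino and gives 40000 nM, the highest number of the three: a 3.3-fold higher number from compound 1 to compound 3 (0.52 log units; beyond the scatter), and a 3.3-fold higher number from compound 2 to compound 3 (0.52 log units; beyond the scatter).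

Compound 4 `Oc1ccc2oc(Cc3ccccc3)cc2c1CN1CCCC(O)C1` is the next step from compound 3: 3-hydroxypiperidin-1-yl in place of methoxy(methyl)amino on a saturated chain carbon bound to an aromatic carbon. The two measured steps that bear on this change are the two into compound 3, each a modest rise in number when methoxy(methyl)amino replaced an amine whose nitrogen carried only carbon substituents. Compound 4 reverses that feature: the nitrogen of the 3-hydroxypiperidin-1-yl group again bears only carbon, now within a six-membered non-aromatic ring. For the measured compounds named here, the hydroxy group on that ring has no counterpart among the measured pairs and remains unassessed. The expectation is therefore a modest fall in number, roughly undoing the steps into compound 3; the estimated step is a 3.3-fold lower number from compound 3 to compound 4 (0.52 log units; beyond the scatter). Compound 4 is expected to give about 12000 nM in this assay, within 5000 nM to 30000 nM.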

Compound 4, half-maximal inhibitory concentration: 11000 nM
For compound 4 the middle estimate is 1.1-fold (0.04 log units) above the measured one, and the stated range covers the measured number.
By their numbers in this assay, from the lowest: compounds 4, 1 and 2 (each within the scatter of the next); then compound 3.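

In this assay, on a saturated chain carbon bound to an aromatic carbon, a six-membered non-aromatic ring on the amine nitrogen returns the number from the level of compound 3, with a 3.6-fold lower number from compound 3 to compound 4 (0.56 log units; beyond the scatter). The comparisons with the two open-chain amines read a 1.1-fold lower number from compound 2 to compound 4 (0.04 log units; within the scatter) and a 1.1-fold lower number from compound 1 to compound 4 (0.04 log units; within the scatter), so diethylamino, benzyl(methyl)amino and 3-hydroxypiperidin-1-yl do not separate, even though 3-hydroxypiperidin-1-yl brings a hydrogen-bond donor that methoxy(methyl)amino lacks, and among these four compounds only compound 3, with oxygen on the amine nitrogen, stands apart. No measurement at hand accounts for any of these steps.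

The contributions of the ring and its hydroxy group remain unseparated, and unsubstituted piperidin-1-yl read against compound 4 would divide them. Also open, on these data alone, is whether any amine at this place gives a number clearly lower than those of compounds 1, 2 and 4, with morpholin-4-yl or a primary amine as candidates, and whether the higher number of compound 3 recurs with another oxygen-bearing nitrogen such as ethoxy(methyl)amino.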